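Toward a cyanophenyl sulfonamide in the DLD-1 antiproliferation series

The source may hold more compounds than are shown below. What is called first, only, known or untested is meant among the compounds shown, and "the series" means these compounds.

Three sulfonamides built on a shared core have been measured in a functional assay on DLD-1 cells (Homo sapiens) for antiproliferative activity, read by CellTiter-Glo, with a stated time of 72 h; on this read-out lower numbers stand for stronger inhibition and higher numbers for weaker inhibition. Compound 1 `Cc1nc(Cl)sc1S(=O)(=O)N1CCC(N2CCC(C)CC2)CC1` gives 1.6 nM. Compound 2 `Cc1ccc(S(=O)(=O)N2CCC(N3CCC(C)CC3)CC2)cc1C` gives 24 nM, and compound 3 `Cc1cccc(S(=O)(=O)N2CCC(N3CCC(C)CC3)CC2)c1` gives 25 nM, the highest of the three numbers; its nearest neighbour is compound 2, within the scatter, and its furthest is compound 1, well beyond it. Among the measured compounds shown here, the two large steps so far, a 15-fold higher number from compound 1 to compound 2 (1.18 log units; beyond the scatter) and a 16-fold higher number from compound 1 to compound 3 (1.19 log units; beyond the scatter), both replace the thiazolyl ring with a methyl-bearing phenyl, whereas a 1.0-fold higher number from compound 2 to compound 3 (0.02 log units; within the scatter) shows that dropping one methyl changes nothing measurable.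

Compound 4 `CC1CCN(C2CCN(S(=O)(=O)c3ccc(C#N)cc3)CC2)CC1` is the next step from compound 3: 4-cyanophenyl in place of 3-methylphenyl on a sulfonyl sulfur. For the measured compounds named here, no measured step in this assay speaks to a nitrile on the phenyl ring, so the only guidance is that both phenyl sulfonamides sit close together. Compound 4 is therefore expected to stay near compound 3, with the step of a 1.2-fold higher number from compound 3 to compound 4 (0.08 log units; within the scatter) not clearly beyond the scatter, and its value is estimated at 30 nM, within 8 nM to 120 nM.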

Compound 4, half-maximal inhibitory concentration: 2800 nM
Compound 4: the middle estimate sits 93-fold (1.97 log units) below what was measured; the whole stated range lies below it.
By their numbers in this assay, from the lowest: compound 1; then compounds 2 and 3 (each within the scatter of the next); then compound 4.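

In this assay the sulfonyl sulfur position turns out not to tolerate every substituted phenyl group: dropping one methyl had changed nothing measurable, yet 4-cyanophenyl gives a 110-fold higher number from compound 3 to compound 4 (2.05 log units; beyond the scatter) and a 120-fold higher number from compound 2 to compound 4 (2.07 log units; beyond the scatter). What the phenyl ring carries therefore matters at this position, and a phenyl sulfonamide does not by itself settle the number. Set against the 2-chloro-4-methyl-1,3-thiazol-5-yl group, the same change gives a 1800-fold higher number from compound 1 to compound 4 (3.24 log units; beyond the scatter), and nothing available here bears on the reason for these steps.

The compounds shown leave open whether the outcome follows the nitrile itself or its place on the ring, which a 3-cyanophenyl group would address. They also leave open how a primary amide, a methoxy group or a fluorine on the phenyl ring would read out.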